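Swapping the pendant aryl ring on a shared amide core

The source may hold more compounds than are shown below. What is called first, only, known or untested is meant among the compounds shown, and "the series" means these compounds.

Three compounds share one core and differ only in the aryl ring hanging from the pyridine. Compound 1 `O=C(Nc1ccc(Oc2ccnc3[nH]ccc23)c(F)c1)c1ccc(-c2ccc(F)cc2)cn1` gives 6010 nM in a functional assay on A549 cells (Homo sapiens) for cytotoxicity, read by MTT assay, with a stated time of 72 h; on this read-out higher numbers stand for weaker inhibition and lower numbers for stronger inhibition. Compound 2 `O=C(Nc1ccc(Oc2ccnc3[nH]ccc23)c(F)c1)c1ccc(-c2ccc(Cl)cc2)cn1` gives 10000 nM in this assay, and the step of a 1.7-fold higher number from compound 1 to compound 2 (0.22 log units; within the scatter) is too small to count. Compound 3 `CCc1ccc(-c2ccnc(C(=O)Nc3ccc(Oc4ccnc5[nH]ccc45)c(F)c3)c2)cc1` gives 3370 nM; that number sits within the scatter of compound 1 and is beyond the scatter below compound 2, so compound 3 stands at the low end without standing clearly apart. Compound 4 `O=C(Nc1ccc(Oc2ccnc3[nH]ccc23)c(F)c1)c1cc(-c2ccc(F)cc2F)ccn1` differs from compound 3 by 2,4-difluorophenyl in place of 4-ethylphenyl on an aromatic carbon. Going by the values given here, the only measured step, the one from compound 1 to compound 2, swaps one halogen for another on that ring and stays within the scatter, which offers no sign that changes on this ring move the numbers much. Compound 4 is therefore expected to give 5000 nM, with a likely range from 1700 nM to 15000 nM. This amounts to an expected 1.5-fold higher number from compound 3 to compound 4 (0.17 log units; within the scatter), a step not beyond the scatter.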

Compound 4, half-maximal inhibitory concentration: > 10000 nM
Compound 4: a limit, no number; the forecaster's own chance of this, stated with the estimate: 10%; middle value at least 2.0-fold (0.30 log units) from the limit.
By their numbers in this assay, from the lowest: compounds 3, 1 and 2 (each within the scatter of the next, the first and the last beyond it).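

In this assay, on these data alone, compound 4 gives > 10000 nM, which is a limit and not a number, so the full size of the change stays unknown: the limit of > 10000 nM in this assay, at which 1 of the 4 values shown sits. Even so, the change reads as an at least 2.9-fold higher number from compound 3 to compound 4 (0.47 log units; beyond the scatter), so the group at this place, opposite the ring nitrogen, can shift the reading clearly, unlike the earlier halogen swap, a 1.7-fold higher number from compound 1 to compound 2 (0.22 log units; within the scatter). The two groups have the same heavy-atom count and each is one aromatic ring of carbon only, so those counts do not separate them; what differs is the substitution on the ring.

As far as these compounds go, with one pair at this place, it stays open whether losing the ethyl group or gaining the two fluorines matters more. A plain phenyl ring or a 4-methoxyphenyl ring here would help to separate the two.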